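Acetyl in place of the ring-nitrogen chain

This account rests on a few compounds, and the source may have more. Where it says the series, first, only, none or still open, it means among the compounds named here.

Three compounds of the shared core, all measured in an ADME assay on L929 cells (Mus musculus) for cytotoxicity, read by resazurin assay, with a stated time of 48 h (on this read-out higher numbers stand for lower toxicity in this test and lower numbers for higher toxicity in this test), frame this step. Compound 1 `C#CCn1c2ccc([N+](=O)[O-])cc2c(=O)n1Cc1ccccc1` gives 195000 nM. Compound 2 `O=C(O)CCCn1c2ccc([N+](=O)[O-])cc2c(=O)n1Cc1ccccc1` is reported only as a limit of the assay, > 256000 nM. Compound 3 `CNC(=O)CCCn1c2ccc([N+](=O)[O-])cc2c(=O)n1Cc1ccccc1` likewise returns only a limit, > 256000 nM. Two of the three values therefore sit at the limit of > 256000 nM in this assay, at which 2 of the 3 values shown sit, and compound 3 stands at that ceiling rather than at a number.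

The steps measured so far are small or unreadable: an at least 1.3-fold higher number from compound 1 to compound 2 (0.11 log units; that floor lies within the scatter) and an at least 1.3-fold higher number from compound 1 to compound 3 (0.11 log units; that floor lies within the scatter) are floors that lie within the scatter, and a step that the two limits leave unreadable from compound 2 to compound 3 cannot be read because both ends are limits.

Compound 4 `CC(=O)n1c2ccc([N+](=O)[O-])cc2c(=O)n1Cc1ccccc1` is not yet measured. It differs from compound 3 in one place: acetyl in place of 3-(methylcarbamoyl)propyl on an aromatic nitrogen. Among the compounds with values here, no measured step replaces a chain on that nitrogen by acetyl, so the step from compound 3 to compound 4 has no direct precedent; the nearest evidence is that all three measured compounds lie at or close to the ceiling. The expectation is a step of an at least 1.2-fold lower number from compound 3 to compound 4 (0.10 log units; that floor lies within the scatter), no larger than the scatter, with the outcome as likely to be a limit again as a number. The estimated value for compound 4 is 200000 nM, between 90000 nM and 256000 nM.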

Compound 4, concentration lethal to 50% of the cells: > 256000 nM
Compound 4 ended at the assay's limit; the forecaster's own chance of this, stated with the estimate: 50%; middle value at least 1.2-fold (0.10 log units) from the limit.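

In this assay compound 4 also returns only a limit, > 256000 nM. The chain on the aromatic nitrogen can thus be cut from 3-(methylcarbamoyl)propyl, with 7 heavy atoms and 1 hydrogen-bond donor, to acetyl, with 3 heavy atoms and 0 hydrogen-bond donors, and the result still stands at the limit and not at a number; the steps to compound 4 from compound 2 and from compound 3 cannot be read, as both ends of each are limits. The only readable comparison is an at least 1.3-fold higher number from compound 1 to compound 4 (0.11 log units; that floor lies within the scatter), so propargyl is not set apart from acetyl beyond the scatter, and at this position the series so far reads mostly as a ceiling: the limit of > 256000 nM in this assay, at which 3 of the 4 values shown sit.

Still open, on these data alone, is whether any group on this nitrogen brings the read-out to a number clearly lower than that of compound 1, for instance a primary amine at the end of a propyl chain or a longer alkyl chain. Also open, as far as these compounds go, is how the values of compound 2, compound 3 and compound 4 lie relative to one another, as limits give no order among them.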